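One flipped stereocentre, compound 3 to compound 4

A few compounds are considered here, and "the series" means these few. Any claim that something is new, unique, unknown or untested is made for them only; others in the source may bear on it.

Compound 1 `COC(=O)N[C@H](C(=O)NN(CC[C@@](O)(Cc1ccccc1)C(=O)N[C@H]1c2ccccc2C[C@H]1O)Cc1ccc(-c2cccnc2)cc1)C(C)(C)C` gives 4900 nM
Compound 2 `COC(=O)N[C@H](C(=O)NN(CC[C@@](O)(Cc1ccccc1)C(=O)N[C@H]1c2ccccc2C[C@H]1O)Cc1ccc(-c2cc(F)cc(F)c2)cc1)C(C)(C)C` gives > 10000 nM (a limit, not a number)
Compound 3 `CNC(=O)[C@@H](NC(=O)[C@](O)(CCN(Cc1ccc(Br)cc1)NC(=O)[C@@H](NC(=O)OC)C(C)(C)C)Cc1ccccc1)C(C)(C)C` gives > 10000 nM (a limit, not a number)

All three readings come from an ADME assay on MT4 cells (Homo sapiens) for cytotoxicity, read by XTT assay, with a stated time of 5 days (a lower number here means that less compound is tolerated, a higher number that more compound is tolerated), and compound 3 stands only at a limit there, namely the limit of > 10000 nM in this assay, at which 2 of the 3 values shown sit (so it has no exact value). Compound 4 `CNC(=O)[C@@H](NC(=O)[C@@](O)(CCN(Cc1ccc(Br)cc1)NC(=O)[C@@H](NC(=O)OC)C(C)(C)C)Cc1ccccc1)C(C)(C)C` has the same atoms and bonds as compound 3 and differs only in configuration as drawn (the two compounds have the same atoms and bonds and differ only in configuration as drawn: 1 of 3 stereo elements differ; a stereocentre at a saturated chain carbon is drawn R in compound 3 and S in compound 4). For the measured compounds named here, the one measured step (an at least 2.0-fold higher number from compound 1 to compound 2 (0.30 log units; that floor lies within the scatter)) puts 3,5-difluorophenyl in place of pyridin-3-yl and changes no configuration, so no measured step shows what this change does. In this assay the expected step is therefore none beyond the scatter (a number no higher from compound 3 to compound 4 (the limit leaves the size open)) and another limit is likely. Compound 4 is estimated at 10000 nM (expected range 5000 nM to 20000 nM).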

Compound 4, half-maximal cytotoxic concentration: > 10000 nM
Compound 4 gave a limit, no number; the forecaster's own chance of this, stated with the estimate: 75%; the middle value sits exactly at the limit.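

For the compounds shown here, compound 3 and compound 4 each give only a limit, not a number, so no step between them can be read. The compounds shown leave open whether the configuration at this saturated chain carbon affects cytotoxicity at all.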